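The source may hold more compounds than are shown below. What is called first, only, known or untested is meant among the compounds shown, and "the series" means these compounds.

Compound 1 `C#CCOc1ccccc1/C=N/Cc1ccc(S(N)(=O)=O)cc1` gives 31000 nM in a functional assay on HT-29 cells (Homo sapiens) for cytotoxicity, read by MTT assay, with a stated time of 24 h; on this read-out lower numbers stand for stronger inhibition and higher numbers for weaker inhibition; compound 2 `C#CCOc1cccc(/C=N/Cc2ccc(S(N)(=O)=O)cc2)c1` gives 104000 nM; compound 3 `O=Cc1ccc(OCc2cn(CCCOc3ccc4ccc(=O)oc4c3)nn2)cc1` gives 100000 nM.

Compound 3 thus stands second highest of the three numbers. Its nearest neighbour is compound 2, whose value lies within the usual scatter of that of compound 3, so no order between the two can be claimed. Compound 1 gives a lower number than compound 3, a gap beyond the scatter. Compound 4 `O=Cc1cc([N+](=O)[O-])ccc1OCc1cn(CCCOc2ccc3ccc(=O)oc3c2)nn1` differs from compound 3 by 2-formyl-4-nitrophenyl in place of 4-formylphenyl on an oxygen on a saturated carbon. Among the compounds with values here, no measured pair shows a change of this kind, so the expectation rests on compound 3 alone. The step of a 1.4-fold lower number from compound 3 to compound 4 (0.15 log units; within the scatter) is expected to stay within the scatter, in no clear direction. Compound 4 is estimated at 70000 nM, with a range from 20000 nM to 200000 nM.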

Compound 4, half-maximal inhibitory concentration: 53600 nM
Beside the measured number, compound 4's estimate is 1.3-fold (0.12 log units) above it; the range from low to high includes it.
By their numbers in this assay, from the lowest: compounds 1, 4, 3 and 2 (each within the scatter of the next, the first and the last beyond it).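

Putting 2-formyl-4-nitrophenyl in place of 4-formylphenyl on an oxygen on a saturated carbon gives the first step read at this position in this assay, a 1.9-fold lower number from compound 3 to compound 4 (0.27 log units; within the scatter), so no order between the two compounds can be claimed. The step adds a nitro group and also moves the formyl group, so the shares of these two differences cannot be told apart. Nothing available accounts for the result. Still open, on these data alone, is whether an amine or a carboxylic acid in place of the formyl group would give a step beyond the scatter.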